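From isopropoxycarbonyl to tert-butoxycarbonyl

A few compounds are considered here, and "the series" means these few. Any claim that something is new, unique, unknown or untested is made for them only; others in the source may bear on it.

Values in a functional assay on the whole organism with Scenedesmus acutus as the target; a lower number here means a stronger inhibitor, a higher number a weaker inhibitor:
- Compound 1 `O=C(O)c1cc(N2C(=O)C3=C(CCCC3)C2=O)ccc1Cl`: > 100000 nM, a limit of the assay and not a number
- Compound 2 `CCOC(=O)c1cc(N2C(=O)C3=C(CCCC3)C2=O)ccc1Cl`: 1380 nM
- Compound 3 `CC(C)OC(=O)c1cc(N2C(=O)C3=C(CCCC3)C2=O)ccc1Cl`: 1000 nM

Compound 3 cannot be told apart from compound 2, since the data show a 1.4-fold lower number from compound 2 to compound 3 (0.14 log units; within the scatter). Compound 4 `CC(C)(C)OC(=O)c1cc(N2C(=O)C3=C(CCCC3)C2=O)ccc1Cl` turns isopropyl into tert-butyl, (methyl in place of hydrogen on a saturated chain carbon bound to an oxygen next to a carbonyl group and two saturated chain carbons). The large steps, an at least 72-fold lower number from compound 1 to compound 2 (1.86 log units; beyond the scatter) and an at least 100-fold lower number from compound 1 to compound 3 (2.00 log units; beyond the scatter), put a chain in place of hydrogen on the oxygen, which is a different change. The closer guide is the earlier addition of methyl, a 1.4-fold lower number from compound 2 to compound 3 (0.14 log units; within the scatter). The expected step in this assay is therefore a 1.1-fold lower number from compound 3 to compound 4 (0.05 log units; within the scatter), with no shift beyond the scatter. For compound 4 the estimate is 900 nM, with an expected range of 350 nM to 2500 nM.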

Compound 4, half-maximal inhibitory concentration: 12900 nM
The estimate for compound 4 lay 14-fold (1.16 log units) below the measured number, outside the stated range (above it).
By their numbers in this assay, from the lowest: compounds 3 and 2 (each within the scatter of the next); then compound 4. At a limit, above all of these: compound 1.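

In this assay, one more methyl on this carbon is no longer a neutral change: tert-butyl gives a weaker inhibitor than either smaller ester chain (a 13-fold higher number from compound 3 to compound 4 (1.11 log units; beyond the scatter); a 9.3-fold higher number from compound 2 to compound 4 (0.97 log units; beyond the scatter)), so ethyl and isopropyl fit here in a way this further branch does not. Compound 4 still outperforms the free acid, compound 1 (an at least 7.7-fold lower number from compound 1 to compound 4 (0.88 log units; beyond the scatter)). Compound 1 stands at a limit of the assay, not a number: (the limit of > 100000 nM in this assay, at which 1 of the 4 values shown sits).

From the compounds shown here alone, whether branching or overall chain size drives the loss remains open. So does what a straight butyl chain or an amide in place of the ester would give.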